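Swapping a Sulfonamide Cap on a Quinoline Antiproliferative Series

This account rests on a few compounds, and the source may have more. Where it says the series, first, only, none or still open, it means among the compounds named here.

Compound 1 `O=C(Nc1ccccc1)Nc1ccc(S(=O)(=O)Nc2ccnc3cc(C(F)(F)F)ccc23)cc1`: 52900 nM
Compound 2 `CC(=O)NS(=O)(=O)c1ccc(N/C(S)=N\c2ccnc3cc(C(F)(F)F)ccc23)cc1`: 58600 nM

In a functional assay on MDA-MB-231 cells (Homo sapiens) for antiproliferative activity, read by sulforhodamine B assay, with a stated time of 48 h (on this read-out higher numbers stand for weaker inhibition and lower numbers for stronger inhibition), compound 1 gives 52900 nM and compound 2 gives 58600 nM. Compound 2 has the higher of the two numbers, but the gap to compound 1 is within the usual scatter, so the two cannot be told apart. Compound 3 `Cc1cc(NS(=O)(=O)c2ccc(N/C(S)=N\c3ccnc4cc(C(F)(F)F)ccc34)cc2)on1` differs from compound 2 by 3-methyl-1,2-oxazol-5-yl in place of acetyl on a sulfonamide nitrogen. Within the data shown here, no pair of measured compounds shows this kind of change, so there is nothing to lean on beyond the two values. The expected step from compound 2 to compound 3 is a 1.3-fold lower number from compound 2 to compound 3 (0.11 log units; within the scatter), none beyond the scatter. For compound 3 in this assay the estimate is 45000 nM, between 15000 nM and 120000 nM.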

Compound 3, half-maximal inhibitory concentration: 80300 nM
Estimate against measurement, compound 3: 1.8-fold (0.25 log units) below, and the stated range covers the measured number.
By their numbers in this assay, from the lowest: compounds 1, 2 and 3 (each within the scatter of the next).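

Putting 3-methyl-1,2-oxazol-5-yl, with its five-membered aromatic ring, in place of acetyl on a sulfonamide nitrogen gives a 1.4-fold higher number from compound 2 to compound 3 (0.14 log units; within the scatter) in this assay. Compound 2 and compound 3 therefore cannot be told apart, so this position accepts a ring-bearing group as well as a small acetyl without a readable shift in the number. Nothing measured here offers an explanation for this result. Still open, from the compounds shown here alone, is whether a plain hydrogen, a phenyl ring or a longer chain such as butyl on this nitrogen would give a number clearly different from these.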